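A few compounds are considered here, and "the series" means these few. Any claim that something is new, unique, unknown or untested is made for them only; others in the source may bear on it.

In a functional assay on the whole organism for antagonist activity, with Mus musculus as the target (on this read-out lower numbers stand for an effect already at smaller amounts and higher numbers for an effect only at larger amounts of compound), compound 1 `COc1cc(N)c(Cl)cc1NC(=O)C1CCN(Cc2ccsc2)CC1` gives 3.4 mg/kg. Compound 2 `COc1cccc(CN2CCC(C(=O)Nc3cc(Cl)c(N)cc3OC)CC2)c1` gives in this assay > 4 mg/kg, which is a limit of the assay and not a number. Compound 3 `COc1cc(N)c(Cl)cc1NC(=O)C1CCN(Cc2ccc(O)cc2)CC1` likewise gives in this assay only a limit, > 8 mg/kg. So compound 3 stands at a limit rather than at a number, and one further value among the three is a limit too, which leaves a step that the two limits leave unreadable from compound 2 to compound 3 unreadable. Among the compounds with values here, the step of an at least 2.3-fold higher number from compound 1 to compound 3 (0.37 log units; beyond the scatter) is the one readable comparison that ends at compound 3, and an at least 1.1-fold higher number from compound 1 to compound 2 (0.07 log units; that floor lies within the scatter) sits within the scatter.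

Compound 4 `CCCN1CCC(C(=O)Nc2cc(Cl)c(N)cc2OC)CC1` differs from compound 3 by ethyl in place of 4-hydroxyphenyl on a saturated chain carbon bound to an amine nitrogen in a ring. The aromatic ring that, in an at least 2.3-fold higher number from compound 1 to compound 3 (0.37 log units; beyond the scatter), went with a weaker effect is thus the group that leaves on the way to compound 4. Within the data shown here, none of the measured steps exchanges an aromatic group for a short chain, so the direction of an at least 1.3-fold lower number from compound 3 to compound 4 (0.12 log units; that floor lies within the scatter) is expected only loosely, and the limit at compound 3 leaves room for a move to smaller numbers. Compound 4 is therefore estimated to give in this assay about 6 mg/kg, expected to lie between 2 mg/kg and 20 mg/kg.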

Compound 4, dose for half-maximal effect: > 10 mg/kg
Compound 4: only a limit was reported (the forecaster's own chance of this, stated with the estimate: 45%); middle value at least 1.6-fold (0.22 log units) from the limit.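

Within the data shown here, compounds 1 to 3 all carry a ring on this saturated chain carbon bound to an amine nitrogen in a ring, and compound 4 is the first with ethyl there, which has no ring at all. In this assay, removing the ring brings no visible gain: the comparison reads an at least 2.9-fold higher number from compound 1 to compound 4 (0.46 log units; beyond the scatter), so ethyl in place of thiophen-3-yl goes with a weaker effect, much as 4-hydroxyphenyl does in the step of an at least 2.3-fold higher number from compound 1 to compound 3 (0.37 log units; beyond the scatter). Compound 4 gives > 10 mg/kg, which is a limit and not a number, and the steps to it from compound 2 and from compound 3 cannot be read.

As far as these compounds go, with only compound 1 giving a number, the order among ethyl, 4-hydroxyphenyl and 3-methoxyphenyl at this place stays open. Also open, from the compounds shown here alone, is whether a longer chain, or a chain ending in an amine or a carboxylic acid, would come close to compound 1 at 3.4 mg/kg.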